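Removing the Bromo Group from Compound 1

The source may report more compounds than this note shows. Statements on the series, on what has been measured and on what is new or still open speak of the compounds shown alone.

Of the compounds shown here, three have been measured in a functional assay on MDA-MB-231 cells (Homo sapiens) for cytotoxicity, read by sulforhodamine B assay, with a stated time of 48 h; on this read-out higher numbers stand for weaker inhibition of growth and lower numbers for stronger inhibition of growth. Compound 1 `Cc1ccc2nc(/N=C3\C(=O)N(CN(c4ccccc4)c4ccccc4)c4cccc(Br)c43)sc2c1` gives 75100 nM, the highest of the three numbers and therefore the weakest inhibition of growth among them. Compound 2 `O=C1C(=O)N(CN2CCCCC2)c2cccc(Cl)c21` gives 26500 nM in this assay, and compound 3 `CCN(CC)CN1C(=O)/C(=N\c2nc3ccc(C)cc3s2)c2c(Cl)cccc21` gives 20400 nM. Both of these numbers lie below that of compound 1 by a gap beyond the usual scatter, but neither compound differs from compound 1 in only one place, so the comparison says nothing about any single structural change.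

Compound 4 `Cc1ccc2nc(/N=C3\C(=O)N(CN(c4ccccc4)c4ccccc4)c4ccccc43)sc2c1` differs from compound 1 in one place: hydrogen in place of bromo on an aromatic carbon. Within the data shown here, no measured pair in this set shows the effect of such a change, so the expectation rests on compound 1 alone and carries wide uncertainty. For compound 4 the step of a 1.2-fold lower number from compound 1 to compound 4 (0.06 log units; within the scatter) is expected to be no larger than the scatter, in either direction. Compound 4 is therefore expected to give about 65000 nM in this assay, with a plausible range from 20000 nM to 200000 nM.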

Compound 4, concentration for 50% growth inhibition: 34100 nM
Estimate against measurement, compound 4: 1.9-fold (0.28 log units) above; the range from low to high includes it.
By their numbers in this assay, from the lowest: compounds 3, 2 and 4 (each within the scatter of the next); then compound 1.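

In this assay, among these compounds, the change of bromo to hydrogen gives the first single-place comparison in this set, and it shows a 2.2-fold lower number from compound 1 to compound 4 (0.34 log units; beyond the scatter) as a modest move towards stronger inhibition of growth. At this aromatic carbon, ortho to a fused ring and meta to a fused ring, the bromo is therefore not needed for the growth inhibition seen with compound 1, and hydrogen serves at least as well on this read-out. Nothing shown here explains why the number falls.

A fluoro, a methoxy or an amine on this same carbon would help show whether any group there gives a higher number or whether this is particular to bromo. From the compounds shown here alone, it also remains open whether the same step would appear if other parts of compound 1 were changed as well.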